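A few compounds are considered here, and "the series" means these few. Any claim that something is new, unique, unknown or untested is made for them only; others in the source may bear on it.

For the measured compounds named here, compound 3 `CCOC(=O)C1=C(N/N=C(/C(=O)Br)c2ccc(Cl)cc2)Nc2[nH]nc(C)c2C1c1ccc(N(C)C)cc1` stands second highest of the three numbers so far: in a functional assay on HepG2 cells (Homo sapiens) for inhibition, read by MTT assay, with a stated time of 48 h (a lower number here means a stronger inhibitor, a higher number a weaker inhibitor), compound 3 gives 50300 nM. Nearest is compound 1 `CCOC(=O)C1=C(N/N=C(/Br)c2ccccc2)Nc2[nH]nc(C)c2C1c1ccc(N(C)C)cc1`, which in this assay gives 72000 nM; the step of a 1.4-fold lower number from compound 1 to compound 3 (0.16 log units; within the scatter) is within the scatter. Furthest is compound 2 `CCOC(=O)C1=C(N)Nc2[nH]nc(C)c2C1c1ccc(N(C)C)cc1`, which in this assay gives 4240 nM; the step of a 12-fold higher number from compound 2 to compound 3 (1.07 log units; beyond the scatter) is large.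

Compound 4 `CCOC(=O)C1=C(N/C=N/c2ccc(C)cc2)Nc2[nH]nc(C)c2C1c1ccc(N(C)C)cc1` is not yet measured. Relative to compound 3 the change is a group of 9 heavy atoms (8 carbon, 1 nitrogen; one six-membered aromatic ring of carbon only) in place of a group of 12 heavy atoms (8 carbon, 1 nitrogen, 1 oxygen, 1 chlorine, 1 bromine; one six-membered aromatic ring of carbon only), on an amine nitrogen.

Both substitutions on this amine nitrogen seen so far raised the number strongly: a 17-fold lower number from compound 1 to compound 2 (1.23 log units; beyond the scatter) in reverse, and a 12-fold higher number from compound 2 to compound 3 (1.07 log units; beyond the scatter). Exchanging one such group for another, a 1.4-fold lower number from compound 1 to compound 3 (0.16 log units; within the scatter), stayed within the scatter. Compound 4 keeps a group on that nitrogen, so the expectation is a number close to compound 3 rather than a return toward compound 2; the estimated step is a 1.3-fold lower number from compound 3 to compound 4 (0.10 log units; within the scatter), essentially none beyond the scatter. Compound 4 is therefore expected to give about 40000 nM in this assay, in the range 12000 nM to 130000 nM.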

Compound 4, half-maximal inhibitory concentration: 44400 nM
For compound 4 the middle estimate is 1.1-fold (0.05 log units) below the measured one, and the stated range covers the measured number.
By their numbers in this assay, from the lowest: compound 2; then compounds 4, 3 and 1 (each within the scatter of the next).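

In this assay a third group on the amine nitrogen falls in with the other two: a 1.1-fold lower number from compound 3 to compound 4 (0.05 log units; within the scatter) and a 1.6-fold lower number from compound 1 to compound 4 (0.21 log units; within the scatter) both stay within the scatter, even though the group in compound 4 holds no bromine, chlorine or oxygen. Against the unsubstituted amine the gap remains large, a 10-fold higher number from compound 2 to compound 4 (1.02 log units; beyond the scatter), so the higher numbers of the substituted compounds do not depend on bromine being present, and compound 2 is the only one clearly apart from the rest. No supporting data bear on why substitution at this nitrogen goes with a higher number.

The compounds shown leave open whether a small group on this nitrogen, such as methyl or acetyl, gives the same higher number as the groups carrying an aromatic ring. On these data alone, how an amine or a carboxylic acid on that aromatic ring would read also remains open.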